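Trimming the Amide Side Chain of a Weak Inhibitor

This account rests on a few compounds, and the source may have more. Where it says the series, first, only, none or still open, it means among the compounds named here.

Compound 1 `CCN(CC)C(=O)COc1ccc2cc(C(O)(C(F)(F)F)C(F)(F)F)c(O)cc2c1` and compound 2 `Oc1c(-c2ccccc2)cccc1C(O)(C(F)(F)F)C(F)(F)F` share a fluorinated carbinol next to a phenol. In an assay on isolated protein for inhibition of tyrosine-protein phosphatase non-receptor type 13 (Homo sapiens), read by spectrophotometry (a higher number here means a weaker inhibitor, a lower number a stronger inhibitor), compound 1 reaches only the assay limit of > 20000 nM, so its strength is known just as a bound. In this assay compound 2 gives 449000 nM. Compound 3 `CCCNC(=O)COc1ccc2cc(C(O)(C(F)(F)F)C(F)(F)F)c(O)cc2c1` arises from compound 1 through the change (propylamino in place of diethylamino on a carbonyl carbon), propylamino in place of diethylamino on a carbonyl carbon. Because the limit of > 20000 nM in this assay, at which 1 of the 2 values shown sits, is all that is known of compound 1, the step that the limit leaves unreadable from compound 1 to compound 3 is expected to stay within scatter. Compound 3 is therefore estimated at 40000 nM, within 15000 nM to 150000 nM.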

Compound 3, half-maximal inhibitory concentration: > 20000 nM
Compound 3: a limit, no number; the forecaster's own chance of this, stated with the estimate: 70%; the middle value does not contradict the limit.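

No step can be read between compound 1 and compound 3: each result is an assay limit, not a number. Going by these compounds, how strongly either compound inhibits, and what propylamino in place of diethylamino does, remains open.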